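Replacing the fluoro group of compound 3 with hydrogen

The source may report more compounds than this note shows. Statements on the series, on what has been measured and on what is new or still open speak of the compounds shown alone.

compound 1 `O=C(Nc1ccc(C(F)(F)F)cc1)c1cc(Cl)ccc1O` gives 510 nM
compound 2 `O=C(Nc1ccc(C(F)(F)F)cc1)c1cc(F)ccc1O` gives 490 nM
compound 3 `O=C(Nc1ccc(C(F)(F)F)cc1)c1cc(Br)c(F)cc1O` gives 450 nM

These values come from a functional assay on HL-60 cells (Homo sapiens) for cytotoxicity, read by luminescence and CellTiter-Glo, with a stated time of 3 days (on this read-out lower numbers stand for stronger inhibition and higher numbers for weaker inhibition), and compound 3 lies within the scatter of both compound 1 and compound 2. Compound 4 `O=C(Nc1ccc(C(F)(F)F)cc1)c1cc(Br)ccc1O` differs from compound 3 by one change hydrogen in place of fluoro on an aromatic carbon in which hydrogen stands in place of fluoro on an aromatic carbon. For the measured compounds named here, no measured step removes a fluoro group. The nearest evidence is a 1.0-fold lower number from compound 1 to compound 2 (0.02 log units; within the scatter) for fluoro in place of chloro on an aromatic carbon, a step within the scatter. No step beyond the scatter is therefore expected in this assay for this change. The estimated step is a 1.1-fold higher number from compound 3 to compound 4 (0.03 log units; within the scatter) and so stays within the scatter. For compound 4 the estimated value is 480 nM within an expected range from 250 nM to 920 nM on this evidence.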

Compound 4, half-maximal inhibitory concentration: 580 nM
Compound 4: middle estimate off by 1.2-fold (0.08 log units), on the low side, within the range that was stated.
By their numbers in this assay, from the lowest: compounds 3, 2, 1 and 4 (each within the scatter of the next).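

In this assay, hydrogen in place of fluoro on the aromatic carbon ortho to a bromo group gives no step beyond the scatter (a 1.3-fold higher number from compound 3 to compound 4 (0.11 log units; within the scatter)). For the compounds shown here, at the carbon that holds the halogen in the earlier compounds, bromo in place of fluoro (a 1.2-fold higher number from compound 2 to compound 4 (0.07 log units; within the scatter)) and bromo in place of chloro (a 1.1-fold higher number from compound 1 to compound 4 (0.06 log units; within the scatter)) also stay within the scatter. Nothing available here bears on the cause of these steps. The compounds shown leave open whether an amine or a carboxylic acid on either carbon would give a step beyond the scatter.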